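This account rests on a few compounds, and the source may have more. Where it says the series, first, only, none or still open, it means among the compounds named here.

Compound 1 `COc1ccc(/C=C/C(=O)c2cccc(-c3ccc(F)cc3)c2)cc1`: 8350 nM
Compound 2 `COc1cc(/C=C/C(=O)c2ccc(N)c(-c3ccc(F)cc3)c2)cc(Br)c1O`: 22900 nM
Compound 3 `COc1ccc(/C=C/C(=O)c2ccc(NC(C)=O)c(-c3ccc(F)cc3)c2)cc1OC`: 5350 nM

In a functional assay on SW480 cells (Homo sapiens) for cytotoxicity, read by sulforhodamine B assay, with a stated time of 48 h (on this read-out lower numbers stand for stronger inhibition and higher numbers for weaker inhibition), compound 1 gives 8350 nM. This value lies within the usual scatter of compound 3 at 5350 nM, so the two cannot be told apart. Compound 2 gives 22900 nM, a higher number beyond the scatter of compound 1, which means weaker inhibition.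

The next compound is compound 4 `COc1ccc(/C=C/C(=O)c2ccc(N)c(-c3ccc(F)cc3)c2)cc1`, which has amino in place of hydrogen on an aromatic carbon of the core of compound 1, ortho to a 4-fluorophenyl group and para to a large group: amino in place of hydrogen on an aromatic carbon. Within the data shown here, no measured pair isolates this change. Compound 2 also carries the amino group and gives 22900 nM, but it differs from compound 4 elsewhere too, so it tilts the expectation only slightly towards a higher number in this assay. The expected change, a 1.2-fold higher number from compound 1 to compound 4 (0.08 log units; within the scatter), is small and is not expected to go beyond the scatter. For compound 4 the estimated value is 10000 nM, with an expected range from 4000 nM to 25000 nM.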

Compound 4, half-maximal inhibitory concentration: 7230 nM
Beside the measured number, compound 4's estimate is 1.4-fold (0.14 log units) above it; the measured number falls inside the stated range.
By their numbers in this assay, from the lowest: compounds 3, 4 and 1 (each within the scatter of the next); then compound 2.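

In this assay, amino in place of hydrogen on an aromatic carbon, ortho to a 4-fluorophenyl group and para to a large group, gives a 1.2-fold lower number from compound 1 to compound 4 (0.06 log units; within the scatter) and so leaves the two compounds indistinguishable. Among these compounds, this is the first pair to isolate the amino group, which compound 2 carries only alongside other differences, and it shows that this position accepts the amino group on the core of compound 1 without a change that can be read beyond the scatter. No measured evidence here explains this result.

Still open, going by these compounds, is whether a larger group at this position, such as a dimethylamino group or a carboxylic acid, would move the number beyond the scatter. A single-place comparison is also lacking for the amino group against the acetylamino group of compound 3.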